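A few compounds are considered here, and "the series" means these few. Any claim that something is new, unique, unknown or untested is made for them only; others in the source may bear on it.

Compound 3 `CCc1nc2c(-c3ccc(Cl)cc3Cl)ccnc2n1[C@H](C)C1CC1` gives 0.6 nM in an assay for binding affinity to Corticotropin releasing factor receptor (Rattus norvegicus); a higher number here means a weaker inhibitor, a lower number a stronger inhibitor.
Compound 2 `CCCC(C)n1c(CC)nc2c(-c3ccc(OC)cc3C)ccnc21` gives 0.8 nM in this assay.
Compound 1 `CCC(CCOC)n1c(OC)nc2c(-c3ccc(OC(F)(F)F)cc3Cl)ccnc21` gives 1.9 nM in this assay.

All three compounds share the same fused core and carry a substituted phenyl ring on it; they differ in the groups on the ring nitrogen and on the neighbouring ring carbon, and in the substituents on the phenyl ring. Compound 3 has the lowest number of the three. Its gap to compound 2 is small enough to fall within the scatter of repeated measurements, so the two cannot be told apart; only compound 1 sits clearly higher, beyond the scatter.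

Compound 4 `CCc1nc2c(-c3ccc(Cl)cc3Cl)ccnc2n1C(CC)CC` is the next step: pentan-3-yl in place of 1-cyclopropylethyl on an aromatic nitrogen. The group on the ring nitrogen thus stays a branched, saturated carbon group of the same size, but loses its small ring and its stereocentre. Branched open-chain groups at this position are already seen in compound 1 and compound 2, both of which give low numbers, so no large shift is expected. The step from compound 3 to compound 4 is expected to be a 1.5-fold higher number from compound 3 to compound 4 (0.18 log units; within the scatter), within the scatter. Compound 4 is estimated at 0.9 nM, with a range from 0.3 nM to 2.7 nM.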

Compound 4, inhibition constant: 1 nM
Beside the measured number, compound 4's estimate is 1.1-fold (0.05 log units) below it; measured number inside the range.
By their numbers in this assay, from the lowest: compounds 3, 2, 4 and 1 (each within the scatter of the next, the first and the last beyond it).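

Among these compounds, compound 3 and compound 4 are the first pair here that differ in one place only, so the group on the aromatic nitrogen can finally be read on its own. In this assay, putting pentan-3-yl in place of 1-cyclopropylethyl gives a 1.7-fold higher number from compound 3 to compound 4 (0.22 log units; within the scatter), so the two compounds cannot be told apart, and this position accepts an open-chain group as well as one with a small ring when the rest of the molecule stays the same. The three-membered ring and the defined stereocentre leave together in this single change, and losing both leaves no difference beyond the scatter, although nothing shown explains why these two groups give such similar numbers.

As far as these compounds go, it remains open whether a shorter group such as isopropyl, a longer chain such as heptan-4-yl, or a chain carrying an amine would hold up as well on this position. The mirror-image form of 1-cyclopropylethyl would show whether the stereocentre matters at all, and the same swap on a different phenyl ring would show whether this result carries over.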